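Series notes: dichlorophenoxy to fluorobenzylamino exchange on the core

This account rests on a few compounds, and the source may have more. Where it says the series, first, only, none or still open, it means among the compounds named here.

For the measured compounds named here, compound 1 `Nc1cc(N)c2nc(-c3ccccc3)c(Oc3ccc(Cl)c(Cl)c3)nc2c1` is the only member with a full number in a functional assay on IGROV-1 cells (Homo sapiens) for inhibition, read by sulforhodamine B assay, with a stated time of 48 h (on this read-out higher numbers stand for lower toxicity in this test and lower numbers for higher toxicity in this test), where compound 1 gives 91200 nM. Compound 2 `CCOC(=O)[C@H](CCC(=O)O)NC(=O)c1ccc(Sc2nc3cc(N)cc(N)c3nc2-c2ccccc2)cc1` reaches only a limit in this assay, namely < 100000 nM. Compound 3 `CCOC(=O)[C@H](CCC(=O)O)NC(=O)c1ccc(Oc2nc3cc(N)cc(N)c3nc2-c2ccccc2)cc1` likewise stops at a limit, < 100000 nM. Going by the values given here, compound 1 thus stands close to the limit of < 100000 nM in this assay, at which 2 of the 3 values shown sit, and no measured step exists against which a change could be scaled. Compound 4 `Nc1cc(N)c2nc(-c3ccccc3)c(NCc3ccc(F)cc3)nc2c1` differs from compound 1 by (4-fluorobenzyl)amino in place of 3,4-dichlorophenoxy on an aromatic carbon. Among the compounds with values here, with no comparable step measured, no shift beyond the scatter is expected in this assay from compound 1 to compound 4 in either direction. Compound 4 is estimated at 80000 nM, with a range from 30000 nM to 150000 nM, the expected step being a 1.1-fold lower number from compound 1 to compound 4 (0.06 log units; within the scatter).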

Compound 4, concentration lethal to 50% of the cells: < 100000 nM
Compound 4: only a limit was reported; the forecaster's own chance of this, stated with the estimate: 40%; the middle value does not contradict the limit.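

The step from compound 1 to compound 4 cannot be read, because compound 4 gives only a limit in this assay: the limit of < 100000 nM in this assay, at which 3 of the 4 values shown sit.

From the compounds shown here alone, whether (4-fluorobenzyl)amino in place of 3,4-dichlorophenoxy changes the value in this assay at all stays open.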